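Replacing the 3-iodophenyl group of compound 3

A few compounds are considered here, and "the series" means these few. Any claim that something is new, unique, unknown or untested is made for them only; others in the source may bear on it.

Measured in a functional assay (muscle tissue) with Cavia porcellus as the target; a lower number here means that less compound is needed, a higher number that more compound is needed for the effect:
- compound 1 `COC(=O)C1=C(C)N=C(C)/C(=C(\O)OC)C1c1cc(Cl)cc(Cl)c1`: 93.3 nM
- compound 2 `COC(=O)C1=C(C)N=C(C)/C(=C(\O)OC)C1c1ccc(C#N)cc1`: 3470 nM
- compound 3 `COC(=O)C1=C(C)N=C(C)/C(=C(\O)OC)C1c1cccc(I)c1`: 41.7 nM

Compound 3 has the lowest number of the three. The unmeasured compound 4 `COC(=O)C1=C(C)N=C(C)/C(=C(\O)OC)C1c1ccc(Cl)cc1Cl` carries 2,4-dichlorophenyl in place of 3-iodophenyl on a saturated ring carbon. Among the compounds with values here, two measured steps bear on this change. The 3,5-dichlorophenyl group gives a modest one, a 2.2-fold lower number from compound 1 to compound 3 (0.35 log units; beyond the scatter), and the 4-cyanophenyl group a large one, an 83-fold lower number from compound 2 to compound 3 (1.92 log units; beyond the scatter). The entering group shares chlorine with the group of compound 1 and a substituent at 4 with that of compound 2. A moderate rise in this assay is therefore expected, lying between those two steps. The expected step is a 7.2-fold higher number from compound 3 to compound 4 (0.86 log units; beyond the scatter). For compound 4 the estimated value is 300 nM, with an expected range of 60 nM to 1500 nM.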

Compound 4, half-maximal effective concentration: 640 nM
The estimate for compound 4 lay 2.1-fold (0.33 log units) below the measured number, within the range that was stated.
By their numbers in this assay, from the lowest: compound 3; then compound 1; then compound 4; then compound 2.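

In this assay, the same two chlorines on the phenyl ring do not give the same number when placed differently: 2,4-dichlorophenyl in place of 3,5-dichlorophenyl gives (a 6.9-fold higher number from compound 1 to compound 4 (0.84 log units; beyond the scatter)). The change from 3-iodophenyl is larger (a 15-fold higher number from compound 3 to compound 4 (1.19 log units; beyond the scatter)), yet 2,4-dichlorophenyl still stands lower than 4-cyanophenyl (a 5.4-fold lower number from compound 2 to compound 4 (0.73 log units; beyond the scatter)). Nothing measured here accounts for these differences.

Open, on these data alone, is how a phenyl group with a single chlorine would compare, and whether a methoxy or nitro group at this place would come near compound 3.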